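The source may report more compounds than this note shows. Statements on the series, on what has been measured and on what is new or still open speak of the compounds shown alone.

For the measured compounds named here, compound 2, with the structure `COCc1cc(C)nc2c(S(=O)(=O)c3ccccc3)c(SC)nn12`, is one of two compounds measured so far in a functional assay on HEK293 cells for antagonist activity at 5-hydroxytryptamine receptor 6 (Homo sapiens), read by cAMP accumulation, with a stated time of 2 h; on this read-out lower numbers stand for stronger inhibition and higher numbers for weaker inhibition. In this assay compound 2 gives 155 nM, the higher of the two numbers. Compound 1, with the structure `CSc1nn2ccc(C)nc2c1S(=O)(=O)c1ccc(F)c(Cl)c1`, gives 7.94 nM in this assay, a number well below that of compound 2, and the gap between them lies beyond the usual scatter; the two compounds differ in several places at once, so the gap cannot be tied to any single change. Compound 3, with the structure `CNc1nn2c(COC)cc(C)nc2c1S(=O)(=O)c1ccccc1`, has not yet been measured. It differs from compound 2 in one place: methylamino in place of methylsulfanyl on an aromatic carbon. Going by the values given here, no measured pair shows this exchange, so its effect is unknown. The exchange is expected to lower the number modestly, by the step of a 1.9-fold lower number from compound 2 to compound 3 (0.29 log units; within the scatter). Compound 3 is therefore estimated at 80 nM, with a range from 20 nM to 320 nM.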

Compound 3, inhibition constant: 7.59 nM
Estimate against measurement, compound 3: 11-fold (1.02 log units) above; measured number outside the range, below it.
By their numbers in this assay, from the lowest: compounds 3 and 1 (each within the scatter of the next); then compound 2.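

At this carbon of the five-membered aromatic ring, a small exchange carries a large effect: in this assay, putting methylamino in place of methylsulfanyl gives a 20-fold lower number from compound 2 to compound 3 (1.31 log units; beyond the scatter) while the rest of the molecule stays the same. The position is therefore sensitive to which group it carries, something the earlier pair could not show because those two compounds differ in several places at once. The entering group has one hydrogen-bond donor and the leaving group has none, but nothing available here explains the step.

On these data alone, it remains open whether the size of the step depends on the methyl group on the nitrogen, which the plain amine, dimethylamino or ethylamino at this carbon would test. As far as these compounds go, it is also open whether the same exchange would give a similar step on the core of compound 1 .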